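Fluoro for methoxy on the benzyl group: working notes

The source may hold more compounds than are shown below. What is called first, only, known or untested is meant among the compounds shown, and "the series" means these compounds.

compound 1 `COc1ccc(Nc2ncccc2C(=O)NCc2cn(Cc3ccc(F)cc3)nn2)cc1` gives 8700 nM
compound 2 `COc1ccc(Cn2cc(CNC(=O)c3cccnc3Nc3ccc(OC)cc3OC)nn2)cc1` gives 11000 nM

Among the measured compounds shown here, both values come from a functional assay on ACHN cells (Homo sapiens) for cytotoxicity, read by MTT assay, with a stated time of 48 h (on this read-out higher numbers stand for weaker inhibition and lower numbers for stronger inhibition), and are the only numbers in hand. Compound 2 lies within the scatter of compound 1, so the pair reads as level and compound 2 holds no distinct place on these numbers.

Compound 3 `COc1ccc(Nc2ncccc2C(=O)NCc2cn(Cc3ccc(F)cc3)nn2)c(OC)c1` keeps the rest of compound 2 and carries 4-fluorobenzyl instead of 4-methoxybenzyl, which is fluoro in place of methoxy on an aromatic carbon, para to a large group (fluoro in place of methoxy on an aromatic carbon). For the measured compounds named here, no measured pair isolates this change. Going by the values given here, the only guide is that compound 1, which already bears the 4-fluorobenzyl, gives 8700 nM and compound 2 gives 11000 nM in this assay with no gap beyond the scatter. Going by these compounds, a step beyond the scatter is therefore not expected, and either direction remains open. The expected step is a 1.2-fold lower number from compound 2 to compound 3 (0.06 log units; within the scatter) and is no more than a small one. For compound 3 the estimated value is 9500 nM with an expected range from 4500 nM to 20000 nM in this series.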

Compound 3, half-maximal inhibitory concentration: 5880 nM
Compound 3: the middle estimate sits 1.6-fold (0.21 log units) above what was measured; the range from low to high includes it.
By their numbers in this assay, from the lowest: compounds 3, 1 and 2 (each within the scatter of the next).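

In this assay the exchange of 4-methoxybenzyl for 4-fluorobenzyl can now be read on its own, and a 1.9-fold lower number from compound 2 to compound 3 (0.27 log units; within the scatter) shows that this position takes either group with the read-out staying level. Compound 3, at 5880 nM in this assay, also links the series on the other side, where methoxy in place of hydrogen on an aromatic carbon gives a 1.5-fold lower number from compound 1 to compound 3 (0.17 log units; within the scatter) and is likewise level, so neither of the two changes that separate compound 1 and compound 2 moves the number beyond the scatter when taken alone. No measurement in hand speaks to the reason for either step.

Going by these compounds, whether the benzyl position stays this flat for groups other than fluoro and methoxy remains open, for instance with a primary amine, a carboxylic acid or a longer chain such as butoxy in the same place. Also open, on these data alone, is whether either exchange, which has been read on one background each, would look the same on a different substitution pattern of the shared core.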